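Methoxy for Trifluoromethyl: An Expected Small Step

A few compounds are considered here, and "the series" means these few. Any claim that something is new, unique, unknown or untested is made for them only; others in the source may bear on it.

Of the compounds shown here, two with a shared core have been measured so far. Compound 1 `COc1ccc(-c2nnc(NC(=O)/C=C/c3ccccc3)s2)cc1` gives 0.78 ug/mL in a functional assay on MCF7 cells (Homo sapiens) for antiproliferative activity, read by MTT assay, with a stated time of 48 h (on this read-out lower numbers stand for stronger inhibition and higher numbers for weaker inhibition), and compound 2 `COc1ccc(-c2nnc(NC(=O)/C=C/c3ccc(C(F)(F)F)cc3)s2)cc1` gives 0.79 ug/mL. Among the measured compounds shown here, the one step between them, a 1.0-fold higher number from compound 1 to compound 2 (0.01 log units; within the scatter), puts a trifluoromethyl in place of hydrogen on an aromatic carbon, and it leaves the number essentially where it was. Compound 2 thus carries the higher of the two numbers, but its nearest neighbour, compound 1, lies within the scatter of it, so no order can be read from this pair.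

Compound 3 `COc1ccc(/C=C/C(=O)Nc2nnc(-c3ccc(OC)cc3)s2)cc1` differs from compound 2 in one place: methoxy in place of trifluoromethyl on an aromatic carbon. For the measured compounds named here, the single measured step bears on it only loosely, since it altered the group on the same aromatic carbon, and that step stayed within the scatter. On this ground no step beyond the scatter is expected in this assay from compound 2 to compound 3, so the estimated step of a 1.0-fold higher number from compound 2 to compound 3 (0.01 log units; within the scatter) is small. Compound 3 is therefore expected to give about 0.8 ug/mL in this assay, with a range from 0.4 ug/mL to 1.6 ug/mL.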

Compound 3, half-maximal inhibitory concentration: 0.28 ug/mL
For compound 3 the middle estimate is 2.9-fold (0.46 log units) above the measured one; the whole stated range lies above it.
By their numbers in this assay, from the lowest: compound 3; then compounds 1 and 2 (each within the scatter of the next).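

Until now this position had shown no response in this assay, as hydrogen and trifluoromethyl on this aromatic carbon, para to a large group, stayed within the scatter of each other. Methoxy is the first group here to move the number beyond the scatter, with a 2.8-fold lower number from compound 2 to compound 3 (0.45 log units; beyond the scatter) and a 2.8-fold lower number from compound 1 to compound 3 (0.44 log units; beyond the scatter), so the position is not indifferent to what it carries, though the shift is modest. The two steps read alike, and their starting compounds lie within the scatter of each other. Nothing given here bears on what lies behind the difference.

Among the compounds shown here, what the compounds leave open is how far this reaches: with methoxy the only group that moves the number, they cannot tell whether a hydroxyl, an ethoxy, an amine or a chlorine on the same carbon would follow it or stay with hydrogen and trifluoromethyl. They also leave open whether a second methoxy on this ring would shift the number further, since all three compounds carry at most one group there.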